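The source may hold more compounds than are shown below. What is called first, only, known or untested is meant among the compounds shown, and "the series" means these compounds.

Measured so far in a functional assay on ileum (Cavia porcellus) for antagonist activity, with a stated time of 30 s; on this read-out higher numbers stand for weaker inhibition and lower numbers for stronger inhibition:
compound 1, `O=C(O)c1cc(=O)c2ccc(OCCCCCCCOc3ccccc3)cc2o1`, gives 1.8 ug/mL
compound 2, `O=C(O)c1cc(=O)c2ccc(OCCCCCSc3ccccc3)cc2o1`, gives 0.4 ug/mL
compound 3, `O=C(O)c1cc(=O)c2ccc(OCCCCCOc3cccc(O)c3)cc2o1`, gives 1.5 ug/mL

Where compound 3 stands: two of the three values sit within the scatter of each other, a 1.2-fold lower number from compound 1 to compound 3 (0.08 log units; within the scatter), and both lie above the third, a 3.8-fold higher number from compound 2 to compound 3 (0.57 log units; beyond the scatter). Within the data shown here, the only step beyond the scatter in the set is the exchange of the group at the end of the chain, a 4.5-fold lower number from compound 1 to compound 2 (0.65 log units; beyond the scatter).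

Compound 4, `COc1cccc(OCCCCCOc2ccc3c(=O)cc(C(=O)O)oc3c2)c1`, differs from compound 3 by methyl in place of hydrogen on an oxygen on an aromatic ring. Among the measured compounds shown here, no measured step touches this oxygen on an aromatic ring; the three measured steps all swap the whole group at the chain end (2-phenoxyethyl, phenylsulfanyl, 3-hydroxyphenoxy), so none bears directly on methyl in place of hydrogen here. The closest comparison, 3-hydroxyphenoxy in place of 2-phenoxyethyl, stayed within the scatter, a 1.2-fold lower number from compound 1 to compound 3 (0.08 log units; within the scatter). For the measured compounds named here, with no direct precedent, no step beyond the scatter is expected in this assay for compound 4, no change at the digits printed from compound 3 to compound 4 (within the scatter). Compound 4 is estimated at 1.5 ug/mL, with a range from 0.6 ug/mL to 4 ug/mL.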

Compound 4, half-maximal inhibitory concentration: 1.5 ug/mL
Compound 4: middle estimate and measured number agree at the digits printed; the measured number falls inside the stated range.
By their numbers in this assay, from the lowest: compound 2; then compounds 3, 4 and 1 (each within the scatter of the next).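

Working from this assay, methyl in place of hydrogen on the oxygen on the aromatic ring leaves the number unmoved (no change at the digits printed from compound 3 to compound 4 (within the scatter)), so a free hydroxy at this oxygen is not required for the inhibition seen in this pair. The 3-methoxyphenoxy end group sits with the 3-hydroxyphenoxy end group in its relation to the other two compounds: it stays within the scatter of compound 1 (a 1.2-fold lower number from compound 1 to compound 4 (0.08 log units; within the scatter)) and remains apart from the phenylsulfanyl compound (a 3.8-fold higher number from compound 2 to compound 4 (0.57 log units; beyond the scatter)). No measurement at hand accounts for this outcome.

Still open, on these data alone, is whether a larger ether such as benzyloxy, or an amine or a carboxylic acid at this place, would keep the same number. Unsubstituted phenoxy on the chain of compound 2 would separate the exchange of sulfur for oxygen from the ring substituent.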